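The source may hold more compounds than are shown below. What is called first, only, known or untested is meant among the compounds shown, and "the series" means these compounds.

In an ADME assay on PA-1 cells (Homo sapiens) for cytotoxicity, read by MTT assay, with a stated time of 72 h (on this read-out higher numbers stand for weaker inhibition and lower numbers for stronger inhibition), three compounds have been examined so far, and none of them has produced a number. Compound 1, with the structure `COC(=O)c1cc(C2=C(c3cc(OC)c(OC)c(OC)c3)C(=O)CC2O[SiH2]C(C)(C)C)ccc1OC`, gives > 100 ug/mL, which is a limit of the assay rather than a measured value. Compound 2, with the structure `COc1cc(C2=C(c3cc(C)c(OC)c(C)c3)C(O)CC2=O)cc(OC)c1OC`, likewise gives > 100 ug/mL, again a limit of the assay. Compound 3, with the structure `O/N=C1/CC(O)C(c2ccccc2)=C1c1ccccc1`, gives > 100 ug/mL, also a limit of the assay. So compound 2 stands where every value so far stands: the limit of > 100 ug/mL in this assay, at which 3 of the 3 values shown sit.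

The unmeasured compound is compound 4, with the structure `COc1cc(C2=C(c3cc(C)c(OC)c(C)c3)C(O[SiH2]C(C)(C)C)CC2=O)cc(OC)c1OC`. It differs from compound 2 in one place: a group of 5 heavy atoms (4 carbon, 1 silicon; no ring) in place of a hydrogen atom, on an oxygen on a saturated carbon.

Going by the values given here, no measured pair shows what this kind of change does in this assay, so no size of step can be read from the data. Since compound 1 also carries a group of this sort on an oxygen and gives > 100 ug/mL, the expectation is that the change brings no step beyond the usual scatter, estimated as a step that the limit leaves unreadable from compound 2 to compound 4. Compound 4 is accordingly expected to give about 120 ug/mL, in a range from 50 ug/mL to 300 ug/mL, most likely reported again only as a limit.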

Compound 4, half-maximal inhibitory concentration: 32 ug/mL
For compound 4 the middle estimate is 3.8-fold (0.57 log units) above the measured one, and the stated range ends above it.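

In this assay, going by these compounds alone, a silicon-bearing group without a ring, put in place of a hydrogen atom on an oxygen on a saturated carbon, brings the first readable change at this position: an at least 3.1-fold lower number from compound 2 to compound 4 (0.49 log units; beyond the scatter). Compound 1 also carries a group of this kind on an oxygen, so the group alone does not bring a readable number, and the other change, 4-methoxy-3,5-dimethylphenyl in place of 4-methoxy-3-(methoxycarbonyl)phenyl on a double-bonded ring carbon, goes with an at least 3.1-fold lower number from compound 1 to compound 4 (0.49 log units; beyond the scatter). Compound 4 is the only compound shown that gives a number instead of a limit, and the others stay at that limit: the limit of > 100 ug/mL in this assay, at which 3 of the 4 values shown sit.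

From the compounds shown here alone, both steps start from a limit, so they set only a smallest size, and the true distance from compound 2 or compound 1 to compound 4 remains unknown. The compounds shown also leave open whether the silicon atom is needed, or whether a methyl ether, an acetate ester or a longer carbon chain on the same oxygen would lower the number as well.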